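Capping a Hydroxyl: From Compound 2 to Compound 3

The compounds below may be only part of what the source reports. "The series", "measured", "known", "first", "only" and "open" are said of these compounds alone.

Among the compounds with values here, compound 2 `CN1CCN(c2nc3ccccc3n2CCO)CC1` gives 410 nM in a functional assay on ileum for inhibition of histamine H1 receptor (Cavia porcellus) (a higher number here means a weaker inhibitor, a lower number a stronger inhibitor), the higher of the two numbers measured so far. The other measured compound, compound 1 `CCCOCCn1c(N2CCCN(C)CC2)nc2ccccc21`, gives 16 nM in this assay, a lower number beyond the scatter, although it differs from compound 2 in more than one place. The unmeasured compound 3 `COCCn1c(N2CCN(C)CC2)nc2ccccc21` differs from compound 2 by a single change: methyl in place of hydrogen on an oxygen on a saturated carbon. Within the data shown here, no measured pair shares exactly this change, so the expectation leans on the gap between compound 2 and compound 1. The expected step is a 3.4-fold lower number from compound 2 to compound 3 (0.53 log units; beyond the scatter), toward a lower number. Compound 3 is estimated at 120 nM, with a range from 40 nM to 400 nM.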

Compound 3, half-maximal inhibitory concentration: 13 nM
For compound 3 the middle estimate is 9.2-fold (0.97 log units) above the measured one; the measured number lies below the stated range.
By their numbers in this assay, from the lowest: compounds 3 and 1 (each within the scatter of the next); then compound 2.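

Turning 2-hydroxyethyl into 2-methoxyethyl brings a 32-fold lower number from compound 2 to compound 3 (1.50 log units; beyond the scatter) in this assay. This single pair shows that one methyl on this oxygen, with the rest of the compound unchanged, is enough for a large step. Nothing measured here explains the size of that step.

From the compounds shown here alone, whether an ethyl group on the same oxygen would keep the low number remains open, as does the effect of an amine in place of the hydroxy group. Compound 1 differs from compound 3 in more than one place, so it cannot settle either question.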